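Vinyl to Propoxy, with Only Limits to Go On

The source may report more compounds than this note shows. Statements on the series, on what has been measured and on what is new or still open speak of the compounds shown alone.

Of the compounds shown here, two on a shared core have been tested in an ADME assay on HepG2 cells (Homo sapiens) for cytotoxicity, read by luminescence, with a stated time of 72 h; a lower number here means that less compound is needed, a higher number that more compound is needed for the effect. Compound 1 (`CCOC(=O)c1c(-c2cc(F)cc(OC)c2)[nH]c2cc(OC)ccc2c1=O`) gives only a limit, > 21500 nM. Compound 2 (`C=Cc1cccc(-c2[nH]c3cc(OC)ccc3c(=O)c2C(=O)OCC)c1`) likewise gives only a limit, > 21500 nM, so it has no numerical value and cannot be ranked against compound 1. Among the compounds with values here, the one measured step is a step that the two limits leave unreadable from compound 1 to compound 2, with 3-vinylphenyl in place of 3-fluoro-5-methoxyphenyl on an aromatic carbon. The record therefore comes down to the limit of > 21500 nM in this assay, at which 2 of the 2 values shown sit.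

Compound 3 (`CCCOc1cccc(-c2[nH]c3cc(OC)ccc3c(=O)c2C(=O)OCC)c1`) has propoxy in place of vinyl on an aromatic carbon, meta to a large group: propoxy in place of vinyl on an aromatic carbon. Within the data shown here, no measured step covers this change, and the step from compound 1 has no readable size, so it offers no guide to size or direction. No step beyond the usual scatter is therefore expected, and the estimated change is a step that the limit leaves unreadable from compound 2 to compound 3. Another limit is the most likely report for the new compound. For a numerical reading, compound 3 is estimated at 25000 nM, with an expected range from 10000 nM to 50000 nM.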

Compound 3, half-maximal effective concentration: > 21500 nM
Compound 3 ended at the assay's limit; the forecaster's own chance of this, stated with the estimate: 80%; the middle value lies beyond the limit too.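

In this assay compound 3 gives > 21500 nM, which is a limit and not a number. The change from compound 2 to compound 3 therefore cannot be read, and the record stays where it was: the limit of > 21500 nM in this assay, at which 3 of the 3 values shown sit.

The compounds shown leave open what concentration any of the three needs for the effect, and whether either change of group shifts it.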